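Exchanging One Heteroaryl Sulfide for Another on the Shared Core

The source may report more compounds than this note shows. Statements on the series, on what has been measured and on what is new or still open speak of the compounds shown alone.

Of the compounds shown here, three on one shared core have been measured in a functional assay on HT-29 cells (Homo sapiens) for cytotoxicity, read by MTT assay, with a stated time of 24 h, tested at 1.6 ug/mL; a lower number here means a weaker effect, a higher number a stronger effect of the compound at the concentration tested. Compound 1 `Cn1c(-c2ccc(NC(=O)CCl)cc2)nc(-c2ccccc2)c1-c1ccccc1` gives 14.4%. Compound 2 `Cn1c(-c2ccc(NC(=O)CSc3nc4cc(Cl)ccc4o3)cc2)nc(-c2ccccc2)c1-c1ccccc1` gives 17.4%. Compound 3 `Cn1c(-c2ccc(NC(=O)CSc3nc4ccccc4s3)cc2)nc(-c2ccccc2)c1-c1ccccc1` gives 15.3%, the second highest of the three numbers, though the steps of a number 0.9 percentage points higher from compound 1 to compound 3 (within the scatter) and a number 2.1 percentage points lower from compound 2 to compound 3 (within the scatter) both stay within the scatter, so the three stand level.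

Compound 4 `Cn1cnnc1SCC(=O)Nc1ccc(-c2nc(-c3ccccc3)c(-c3ccccc3)n2C)cc1` awaits measurement. It differs from compound 3 in one place: 4-methyl-4H-1,2,4-triazol-3-yl in place of 1,3-benzothiazol-2-yl on a sulfur. For the measured compounds named here, the steps that bear on this exchange are a number 3 percentage points higher from compound 1 to compound 2 (within the scatter), a number 0.9 percentage points higher from compound 1 to compound 3 (within the scatter) and a number 2.1 percentage points lower from compound 2 to compound 3 (within the scatter); none of them leaves the scatter, whatever group the sulfur carries, and even the chloro of compound 1 reads no differently. The account therefore expects no step beyond the scatter for the new sulfide, that is a number 0.3 percentage points lower from compound 3 to compound 4 (within the scatter). The estimate for compound 4 in this assay is 15%, expected to fall between 7% and 24%.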

Compound 4, a percentage reported as activity, at one concentration (the size of the read-out at that concentration, not a potency): 40.8%
Estimate against measurement, compound 4: 25.8 percentage points below; measured number above the stated range.
By their numbers in this assay, from the lowest: compounds 1, 3 and 2 (each within the scatter of the next); then compound 4.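

In this assay the group on the sulfur proves able to move the read-out, which compounds 1, 2 and 3 had not shown: 4-methyl-4H-1,2,4-triazol-3-yl in place of 1,3-benzothiazol-2-yl gives a number 25.5 percentage points higher from compound 3 to compound 4 (beyond the scatter) and in place of 5-chloro-1,3-benzoxazol-2-yl gives a number 23.4 percentage points higher from compound 2 to compound 4 (beyond the scatter). The same holds against the chloro, with a number 26.4 percentage points higher from compound 1 to compound 4 (beyond the scatter), so the sulfide link alone does not set compound 4 apart, since compounds 2 and 3 carry it too and read level with compound 1. Nothing available explains why this one group stands apart from the others.

As far as these compounds go, what an ethyl group or a hydrogen in place of the 4-methyl would give stays open. So does whether a 1,3,4-oxadiazol-2-yl ring on the sulfur would read with compound 4 or with compound 3.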